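This account rests on a few compounds, and the source may have more. Where it says the series, first, only, none or still open, it means among the compounds named here.

Measured in a functional assay on KB cells (Homo sapiens) for antiproliferative activity, read by sulforhodamine B assay, with a stated time of 3 days; a higher number here means that more compound is needed for the effect, a lower number that less compound is needed:
compound 1 `CCCCc1ccc(-c2cc(=O)c3c(o2)C(CC)(CC)C(=O)C(CC)=C3O)cc1`, 111 uM;
compound 2 `CCC1=C(O)c2c(oc(-c3ccc(OC(F)(F)F)cc3)cc2=O)C(CC)(CC)C1=O`, 36.5 uM;
compound 3 `CCC1=C(O)c2c(oc(-c3ccc(CBr)cc3)cc2=O)C(CC)(CC)C1=O`, a limit, > 46.5 uM.

Compound 3 stands only as a limit in this assay, and so its place among the three measured compounds cannot be fixed. Against compound 1, a step that the limit leaves unreadable from compound 1 to compound 3. Against compound 2, an at least 1.2-fold higher number from compound 2 to compound 3 (0.10 log units; that floor lies within the scatter). For the measured compounds named here, the one fully readable step is a 3.0-fold lower number from compound 1 to compound 2 (0.48 log units; beyond the scatter).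

Compound 4 `CCC1=C(O)c2c(oc(-c3ccc(O)c(O)c3)cc2=O)C(CC)(CC)C1=O` is the next member of the series. Compared with compound 3, the change is 3,4-dihydroxyphenyl in place of 4-(bromomethyl)phenyl on an aromatic carbon. Going by the values given here, no measured pair among compounds 1, 2 and 3 changes a group of this kind, and the only step that starts from compound 3 is read against a limit (the limit of > 46.5 uM in this assay, at which 1 of the 3 values shown sits). The estimate for compound 4 therefore rests on little: a step of an at least 1.1-fold lower number from compound 3 to compound 4 (0.06 log units; that floor lies within the scatter) is expected, with wide uncertainty and a real chance that this assay again returns only a limit. Compound 4 is estimated at 40 uM, between 10 uM and 150 uM.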

Compound 4, concentration for half-maximal effect: 10 uM
Compound 4: middle estimate off by 4.0-fold (0.60 log units), on the high side; the measured number falls inside the stated range.
By their numbers in this assay, from the lowest: compound 4; then compound 2; then compound 1.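

For the compounds shown here, at the ring carbon next to the ring oxygen, 3,4-dihydroxyphenyl in place of 4-(bromomethyl)phenyl gives the only step from compound 3 that is read as beyond the scatter, an at least 4.6-fold lower number from compound 3 to compound 4 (0.66 log units; beyond the scatter). The entering group has hydrogen-bond donors and acceptors where the leaving group has none, at the same count of heavy atoms, and in this assay compound 4 reaches 10 uM, so this position accepts a phenyl carrying two hydroxyl groups. Compound 3 is held only as a limit, > 46.5 uM, and the full size of the step stays unknown: the limit of > 46.5 uM in this assay, at which 1 of the 4 values shown sits.

As far as these compounds go, whether the step comes from the arrival of the hydroxyl groups or from the loss of the bromomethyl group stays open. Also open, from the compounds shown here alone, is whether a phenyl with one hydroxyl group, with two methoxy groups or with an amine would give a similar number.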